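From (methoxycarbonyl)amino to amino on the shared core

The source may report more compounds than this note shows. Statements on the series, on what has been measured and on what is new or still open speak of the compounds shown alone.

Among the compounds with values here, compound 2 `COC(=O)Nc1cccc2c1CCCC2c1c[nH]cn1` is the only compound here with a numerical result: in an assay on isolated protein for binding affinity to Alpha-1D adrenergic receptor (Rattus norvegicus), read by radioligand binding (a lower number here means a stronger inhibitor, a higher number a weaker inhibitor), compound 2 gives 3020 nM. Compound 1 `CC(=O)Nc1cccc2c1CCCC2c1c[nH]cn1` is known only through a limit of the assay. In this assay compound 1 gives < 10000 nM, which is a limit and not a number. The step that the limit leaves unreadable from compound 1 to compound 2 therefore cannot be sized because the limit of < 10000 nM in this assay, at which 1 of the 2 values shown sits, hides one end of it. Compound 3 `Nc1cccc2c1CCCC2c1c[nH]cn1` arises from compound 2 by hydrogen in place of methoxycarbonyl on a nitrogen on an aromatic ring. No measured step bears on this change with a readable size, so its direction stays open on the evidence shown. A modest loss of affinity is nonetheless expected in this assay, with the step of a 2.0-fold higher number from compound 2 to compound 3 (0.30 log units; within the scatter) lying near the edge of the scatter. For compound 3 the estimate in this assay is 6000 nM, within a range from 1500 nM to 25000 nM.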

Compound 3, inhibition constant: 191 nM
The estimate for compound 3 lay 31-fold (1.50 log units) above the measured number, and the stated range ends above it.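

In this assay, the change on a nitrogen on an aromatic ring now has a readable size: hydrogen in place of methoxycarbonyl gives a 16-fold lower number from compound 2 to compound 3 (1.20 log units; beyond the scatter). The earlier compounds shown here offered no readable step at this position, and this step shows that the number on the shared core responds strongly to what sits on this nitrogen, with the free amino form holding the lower number of the two measured compounds. Compound 1, with acetyl on the same nitrogen, is known only through a limit of the assay, and both steps involving it cannot be read because of that limit: the limit of < 10000 nM in this assay, at which 1 of the 3 values shown sits.

As far as these compounds go, whether acetyl behaves like methoxycarbonyl or more like hydrogen stays open. So does what a methyl group or a methanesulfonyl group on this nitrogen would do to the number in this assay.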